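The source may hold more compounds than are shown below. What is called first, only, known or untested is meant among the compounds shown, and "the series" means these compounds.

Three close relatives were tested in a functional assay on A375P cells (Homo sapiens) for cytotoxicity, read by MTT assay, with a stated time of 2 days; a higher number here means a weaker inhibitor, a lower number a stronger inhibitor. Compound 1 `Cc1cccc(N2CCN(CCCNc3nc(NCc4ccco4)c4ccccc4n3)CC2)c1C` gives 3040 nM, compound 2 `Clc1cccc(N2CCN(CCCNc3nc(NCc4ccco4)c4ccccc4n3)CC2)c1Cl` gives 3360 nM, and compound 3 `Clc1cccc(N2CCN(CCCCNc3nc(NCc4ccco4)c4ccccc4n3)CC2)c1Cl` gives 3750 nM. Compound 1 and compound 2 share a core and differ only where (2,3-dimethylphenyl in place of 2,3-dichlorophenyl on an amine nitrogen in a ring); that change made a step of a 1.1-fold lower number from compound 2 to compound 1 (0.04 log units; within the scatter). The difference between the core of compound 2 and the core of compound 3 is not broken down here.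

Compound 4 `Cc1cccc(N2CCN(CCCCNc3nc(NCc4ccco4)c4ccccc4n3)CC2)c1C` is not yet measured. It is made from compound 3 by the same change, (2,3-dimethylphenyl in place of 2,3-dichlorophenyl on an amine nitrogen in a ring). Because the earlier step was a 1.1-fold lower number from compound 2 to compound 1 (0.04 log units; within the scatter), the step from compound 3 to compound 4 in this assay is expected to be about as small, a 1.1-fold lower number from compound 3 to compound 4 (0.04 log units; within the scatter). Compound 4 is therefore estimated at 3400 nM, likely between 1900 nM and 6500 nM.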

Compound 4, half-maximal inhibitory concentration: 3900 nM
Estimate against measurement, compound 4: 1.1-fold (0.06 log units) below, and the stated range covers the measured number.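

In this assay, putting 2,3-dimethylphenyl in place of 2,3-dichlorophenyl made a 1.0-fold higher number from compound 3 to compound 4 (0.02 log units; within the scatter), so the swap leaves no measurable mark on this core. Set beside the earlier case, the change behaves alike on both cores: the same change on two cores in this assay, a 1.1-fold lower number (0.04 log units; within the scatter) from compound 2 to compound 1 and a 1.0-fold higher number (0.02 log units; within the scatter) from compound 3 to compound 4, 1.1-fold (0.06 log units) apart, within the scatter of two such steps

Among the compounds shown here, this shows only that the swap stays silent on these two cores; with neither step beyond the scatter, it does not show how a change with a real effect would carry from one core to another. The compounds shown leave open whether other groups on the same ring nitrogen, such as a plain phenyl or a pyridyl, would shift the number. They also leave open what a longer chain would do.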